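The compounds below may be only part of what the source reports. "The series", "measured", "known", "first", "only" and "open" are said of these compounds alone.

Measured compounds:
compound 1 `COC(=O)c1cc(Cl)ccc1OC(=O)COc1cc(O)c2c(=O)cc(-c3ccccc3)oc2c1` gives 3740 nM in a functional assay on cells (T-cell, Mus musculus, strain BALB/c) for inhibition, read by MTT assay, with a stated time of 72 h; on this read-out higher numbers stand for weaker inhibition and lower numbers for stronger inhibition;
compound 2 `COC(=O)c1cc(O)ccc1OC(=O)COc1cc(O)c2c(=O)cc(-c3ccccc3)oc2c1` gives 29500 nM in this assay;
compound 3 `COC(=O)c1cccc(Cl)c1OC(=O)COc1cc(O)c2c(=O)cc(-c3ccccc3)oc2c1` gives 38700 nM in this assay.

Compound 2 stands second highest of the three numbers. Its nearest neighbour is compound 3, a step of a 1.3-fold higher number from compound 2 to compound 3 (0.12 log units; within the scatter), which is within the scatter. Its furthest is compound 1, a step of a 7.9-fold higher number from compound 1 to compound 2 (0.90 log units; beyond the scatter), which is beyond the scatter.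

The account now turns to compound 4 `COC(=O)c1c(Cl)cccc1OC(=O)COc1cc(O)c2c(=O)cc(-c3ccccc3)oc2c1`, which has not been measured. The change from compound 2 to compound 4 is a group of 11 heavy atoms (8 carbon, 2 oxygen, 1 chlorine; one six-membered aromatic ring of carbon only) in place of a group of 11 heavy atoms (8 carbon, 3 oxygen; one six-membered aromatic ring of carbon only), on an oxygen next to a carbonyl group.

Going by the values given here, two measured steps bear on this. The step of a 1.3-fold higher number from compound 2 to compound 3 (0.12 log units; within the scatter) exchanged the same leaving group for another chlorine-bearing group and stayed within the scatter. The step of a 10-fold higher number from compound 1 to compound 3 (1.01 log units; beyond the scatter) shows that the arrangement of the chloro and methoxycarbonyl groups on the ring can shift the number a great deal. Compound 4 carries a third arrangement, so a step in either direction is possible; the expected step in this assay is a 2.0-fold lower number from compound 2 to compound 4 (0.29 log units; within the scatter), modest and uncertain. Compound 4 is estimated at 15000 nM, with a range from 4000 nM to 50000 nM.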

Compound 4, half-maximal inhibitory concentration: 38900 nM
Compound 4: the middle estimate sits 2.6-fold (0.41 log units) below what was measured, and the stated range covers the measured number.
By their numbers in this assay, from the lowest: compound 1; then compounds 2, 3 and 4 (each within the scatter of the next).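

With the 3-chloro-2-(methoxycarbonyl)phenyl group on the oxygen next to a carbonyl group, the number in this assay joins the high cluster of the set, as the steps (a 1.3-fold higher number from compound 2 to compound 4 (0.12 log units; within the scatter)) and (a 1.0-fold higher number from compound 3 to compound 4 (0.00 log units; within the scatter)) show. The step (a 10-fold higher number from compound 1 to compound 4 (1.02 log units; beyond the scatter)) is much the same in size as the step (a 10-fold higher number from compound 1 to compound 3 (1.01 log units; beyond the scatter)), so among the three chlorine-bearing arrangements shown, only the 4-chloro-2-(methoxycarbonyl)phenyl group of compound 1 stands apart. Nothing shown explains why this one arrangement differs from the other two.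

Still open, going by these compounds, is how a carboxylic acid in place of the methoxycarbonyl group would read in this assay. Also open, on these data alone, is whether compound 1 would keep its standing with bromo or an amine in place of its chloro group.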